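This account rests on a few compounds, and the source may have more. Where it says the series, first, only, none or still open, it means among the compounds named here.

Of the compounds shown here, three built on one shared core have been measured in an in vitro functional assay on HEK285-7 cells for antagonist activity at prostaglandin D2 receptor 2 (Homo sapiens), read by BRET and beta-arrestin recruitment; a lower number here means a stronger inhibitor, a higher number a weaker inhibitor. Compound 1, `O=C(O)Cc1sc(COc2ccc(Cl)cc2)nc1-c1ccc(Cl)cc1`, gives 370 nM in this assay. Compound 3, `O=C(O)Cc1sc(C(c2ccccc2)c2ccccc2)nc1-c1ccc(F)c(F)c1`, gives 43 nM. Compound 2, `O=C(O)Cc1sc(C(c2ccc(F)cc2)c2ccc(F)cc2)nc1-c1ccnc(F)c1`, gives 4.7 nM, the lowest of the three numbers; its nearest neighbour is compound 3, whose number stands higher by a margin beyond the scatter, and compound 1 lies further away still, also beyond the scatter. For the measured compounds named here, no pair of these measured compounds differs in only one place, so no single structural step can be read directly from them.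

Compound 4, `O=C(O)Cc1sc(C(c2ccc(F)cc2)c2ccc(F)cc2)nc1-c1cc(F)nc(F)c1`, has not yet been measured. It differs from compound 2 in one place: fluoro in place of hydrogen on an aromatic carbon. Cut one bond further out, the change reads 2-fluoropyridin-4-yl to 2,6-difluoropyridin-4-yl.

Going by the values given here, no measured pair shows what a second fluoro on this ring does, so the expectation rests on compound 2 alone. The step of a 1.3-fold higher number from compound 2 to compound 4 (0.11 log units; within the scatter) is expected to be small, within the scatter or at most a slight move toward a higher number. Compound 4 is therefore expected to give about 6 nM, with a range from 2.5 nM to 15 nM.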

Compound 4, half-maximal inhibitory concentration: 110 nM
Beside the measured number, compound 4's estimate is 18-fold (1.26 log units) below it; the measured number lies above the stated range.
By their numbers in this assay, from the lowest: compound 2; then compound 3; then compound 4; then compound 1.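

In this assay, fluoro in place of hydrogen on the aromatic carbon next to the ring nitrogen, turning 2-fluoropyridin-4-yl into 2,6-difluoropyridin-4-yl, gives a 23-fold higher number from compound 2 to compound 4 (1.37 log units; beyond the scatter), a large step beyond the scatter. For the compounds shown here, this is the first single-place comparison, and it shows that this position is far from indifferent: one added heavy atom, with no ring, no charge and no hydrogen-bond donor or acceptor counted for it, is enough to weaken inhibition markedly when everything else in compound 2 stays the same. Nothing measured here accounts for the size of this step, so its cause remains unexplained.

The compounds shown leave open whether the loss is specific to fluoro or would also follow from another group at this position, such as chloro, methyl, methoxy or an amine. Going by these compounds alone, they also leave open whether a step of this size would recur on a different substitution pattern elsewhere in the molecule, since only this one pair differs in a single place.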